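The source may report more compounds than this note shows. Statements on the series, on what has been measured and on what is new or still open speak of the compounds shown alone.

Compound 1 `O=C(NCc1ccc(F)cc1)c1nc(Br)c2cccnc2c1NCCCNc1c(C(=O)NCc2ccc(F)cc2)nc(Br)c2cccnc12` and compound 2 `C[C@@H](Nc1c(C(=O)NCc2ccc(F)cc2)nc(Br)c2cccnc12)c1ccccc1` share their core with compound 3 `N[C@H]1CC[C@H](Nc2c(C(=O)NCc3ccccn3)nc(Br)c3cccnc23)CC1`, and compound 4 `N[C@H]1CC[C@H](Nc2c(C(=O)Nc3ccccc3)nc(Br)c3cccnc23)CC1` follows from compound 3 by a single change. In a functional assay on HCT-116 cells (Homo sapiens) for cytotoxicity, read by MTT assay, with a stated time of 72 h (on this read-out higher numbers stand for weaker inhibition and lower numbers for stronger inhibition), compound 1 gives only a limit, > 20000 nM. In this assay compound 2 likewise gives only a limit, > 20000 nM. For compound 3 this assay reports no result, "not determined" (no result reported), so compound 3 stands without a number of its own. Across the compounds measured so far, the picture is simply (the limit of > 20000 nM in this assay, at which 2 of the 3 values shown sit). The step from compound 3 to compound 4 alters the substituent on the amide-type nitrogen: phenyl in place of (pyridin-2-yl)methyl on an amide-type nitrogen. No step between measured compounds is shown, so there is no measured footing for the size of this change in this assay; the expectation is a move no larger than the usual scatter, in no settled direction. The value for compound 4 in this assay is expected to be 20000 nM, within 6000 nM to 50000 nM, and quite possibly reported only as a limit.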

Compound 4, half-maximal inhibitory concentration: 2000 nM
Estimate against measurement, compound 4: 10-fold (1.00 log units) above; the measured number lies below the stated range.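

Going by these compounds alone, compound 3 stands without a number in this assay while compound 4 gives 2000 nM, so no step between the two can be read. Going by these compounds, what phenyl in place of (pyridin-2-yl)methyl on the amide-type nitrogen does to the value, in size or direction, stays open.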